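From Cyclohexyl to 4-Aminophenyl on a Shared Core

The source may report more compounds than this note shows. Statements on the series, on what has been measured and on what is new or still open speak of the compounds shown alone.

Of the compounds shown here, three built on a shared core have so far been measured in a physicochemical assay for solubility, in phosphate buffer, measured as thermodynamic solubility, at pH 7.4 (a lower number here means a less soluble compound, a higher number a more soluble compound), and give a narrow spread of numbers. Compound 1 (`CS(=O)(=O)NC(=O)CCc1cn(-c2ccncc2)nc1-c1ccc(Cl)cc1`) reads 190000 nM in this measurement, and compound 2 (`CS(=O)(=O)NC(=O)CCc1cn(-c2ccc(Cl)cc2)nc1-c1ccccc1Cl`) reads 90000 nM in the same way. Compound 3 (`CS(=O)(=O)NC(=O)CCc1cn(-c2ccc(Br)cc2)nc1C1CCCCC1`) reads 60000 nM and so sits within the scatter of compound 2, while compound 1 stands above it by more than the scatter.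

Compound 4 (`CS(=O)(=O)NC(=O)CCc1cn(-c2ccc(Br)cc2)nc1-c1ccc(N)cc1`) has not yet been measured. Compared with compound 3, it has 4-aminophenyl in place of cyclohexyl on an aromatic carbon, next to the ring nitrogen (4-aminophenyl in place of cyclohexyl on an aromatic carbon). Going by the values given here, no measured pair isolates this change, so the expectation rests on a loose comparison. Compound 1 at 190000 nM and compound 2 at 90000 nM both hold a six-membered aromatic ring of carbon only at that place, but each also differs from compound 4 elsewhere, so they offer only weak guidance. A small rise is estimated, a 1.7-fold higher number from compound 3 to compound 4 (0.22 log units; within the scatter) and expected to stay within the scatter. In this assay compound 4 is estimated at 100000 nM with an expected range from 40000 nM to 250000 nM as its bounds.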

Compound 4, solubility: 160000 nM
Estimate against measurement, compound 4: 1.6-fold (0.20 log units) below; the range from low to high includes it.
By their numbers in this assay, from the lowest: compounds 3, 2, 4 and 1 (each within the scatter of the next, the first and the last beyond it).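

Going by these compounds alone, compounds 3 and 4 form the first pair on the shared core that differs in one place, and they show that this position, on an aromatic carbon of the five-membered aromatic ring next to the ring nitrogen, can shift the read-out in this assay when the 4-bromophenyl group and the 2-((methylsulfonyl)carbamoyl)ethyl group stay fixed. Putting 4-aminophenyl in place of cyclohexyl gives a 2.7-fold higher number from compound 3 to compound 4 (0.43 log units; beyond the scatter) on the same core. Within the data shown here, the step is modest but lies beyond the scatter, something the earlier compounds could not show for this position, since no two of them differed in one place alone. Nothing measured here accounts for the rise.

The step joins two changes, from a non-aromatic ring to an aromatic one and the addition of an amino group, and the compounds shown do not separate them; a plain phenyl at this place, with the 4-bromophenyl group kept, would do so. Going by these compounds, whether the rise carries over to other groups here, such as 4-hydroxyphenyl, 4-carboxyphenyl or a morpholine ring, also stays open.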